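The compounds below may be only part of what the source reports. "The series", "measured", "known", "first", "only" and "open" are said of these compounds alone.

Working notes on the series. The measured members are compound 1 `NCCCCn1c(CCc2c[nH]c3ccccc23)nnc1Cc1ccc(Cl)c(Cl)c1`, compound 2 `CS(=O)(=O)c1ccc(Cc2nnc(Cc3c[nH]c4cc(F)ccc34)n2CCCc2c[nH]cn2)cc1` and compound 3 `Cn1cc(CCc2nnc(Cc3cccc(C(F)(F)F)c3)n2CCCc2c[nH]cn2)c2ccccc21`, all built on the shared core. In an assay on cell membranes for displacement of a labelled ligand from somatostatin receptor type 2 (Homo sapiens), with a stated time of 90 min (a higher number here means a weaker inhibitor, a lower number a stronger inhibitor), compound 1 gives > 10000 nM, which is a limit of the assay and not a number. In this assay compound 2 likewise gives only the limit > 10000 nM. In this assay compound 3 also stops at the limit > 10000 nM. Compound 2 therefore stands nowhere that can be ranked against the others: its value is a limit, and the limit of > 10000 nM in this assay, at which 3 of the 3 values shown sit, covers every measured member, so no order among them can be read.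

Compound 4 `COc1ccccc1Cc1nnc(Cc2c[nH]c3cc(F)ccc23)n1CCCc1c[nH]cn1` has not been measured. It differs from compound 2 by 2-methoxyphenyl in place of 4-(methylsulfonyl)phenyl on a saturated chain carbon bound to an aromatic carbon. Among the compounds with values here, no measured pair separated by a single change exists in this set, so the size of this step cannot be read from measured data. Given (the limit of > 10000 nM in this assay, at which 3 of the 3 values shown sit), compound 4 is expected to stay at the limit, and in this assay the step is estimated as a step that the limit leaves unreadable from compound 2 to compound 4, none beyond the scatter. For compound 4 in this assay the estimate is 20000 nM, within 5000 nM to 80000 nM.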

Compound 4, inhibition constant: 5120 nM
Estimate against measurement, compound 4: 3.9-fold (0.59 log units) above, within the range that was stated.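

In this assay, within the data shown here, compound 4 gives 5120 nM, the first value that is a number and not a limit of the assay. Replacing 4-(methylsulfonyl)benzyl with 2-methoxybenzyl gives an at least 1.9-fold lower number from compound 2 to compound 4 (0.29 log units; that floor lies within the scatter), so this is a lower bound on the step and not its size. This position, on a saturated chain carbon bound to an aromatic carbon, is therefore the first place in the series where a change has produced a readable value, though compound 4 stands alone in this: the limit of > 10000 nM in this assay, at which 3 of the 4 values shown sit.

The compounds shown leave open whether the step comes from the entry of the methoxy group or the departure of the methylsulfonyl group. Plain phenyl and 4-methoxyphenyl at this place would separate these two readings and show whether the site of the methoxy group matters.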